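Trimming the isopropyl of compound 2 to methyl

The compounds below may be only part of what the source reports. "The series", "measured", "known", "first", "only" and "open" are said of these compounds alone.

Compound 2 `CC(C)c1ccc(-c2nc(SCc3cn(CC(=O)NC(=O)Nc4ccccn4)nn3)nc(Nc3cccc(Cl)c3)c2C#N)cc1` gives 13300 nM in a functional assay on ECa-109 cells (Homo sapiens) for inhibition, read by MTT assay, with a stated time of 72 h; on this read-out higher numbers stand for weaker inhibition and lower numbers for stronger inhibition. Compound 1 `CC(C)c1ccc(-c2nc(SCc3cn(CC(=O)NC(=O)Nc4ccccn4)nn3)nc(Nc3ccc(Cl)cc3)c2C#N)cc1` gives 11200 nM in this assay, and a 1.2-fold higher number from compound 1 to compound 2 (0.07 log units; within the scatter). Compound 3 `CC(C)c1ccc(-c2nc(SCc3cn(CC(=O)NC(=O)Nc4ccccn4)nn3)nc(Nc3ccccc3)c2C#N)cc1` reports only a limit in this assay, > 64000 nM. Compound 2 thus holds the higher of the two numbers, though its step from compound 1 is within the scatter. The steps of an at least 5.7-fold higher number from compound 1 to compound 3 (0.75 log units; beyond the scatter) and an at least 4.8-fold higher number from compound 2 to compound 3 (0.68 log units; beyond the scatter) concern the chloro of the chlorophenyl groups, not the position changed here. Compound 4 `Cc1ccc(-c2nc(SCc3cn(CC(=O)NC(=O)Nc4ccccn4)nn3)nc(Nc3cccc(Cl)c3)c2C#N)cc1` differs from compound 2 by methyl in place of isopropyl on an aromatic carbon. Going by the values given here, no measured step touches this group, so compound 4 is expected to show a 1.1-fold higher number from compound 2 to compound 4 (0.05 log units; within the scatter), nothing beyond the scatter in this assay. Compound 4 is therefore estimated at 15000 nM, between 6000 nM and 40000 nM.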

Compound 4, half-maximal inhibitory concentration: 25600 nM
Compound 4: the middle estimate sits 1.7-fold (0.23 log units) below what was measured; low and high end bracket the measured number.
By their numbers in this assay, from the lowest: compounds 1, 2 and 4 (each within the scatter of the next, the first and the last beyond it). At a limit, above all of these: compound 3.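

Going by these compounds alone, the first change at this place, from 4-isopropylphenyl to 4-methylphenyl, gives in this assay a 1.9-fold higher number from compound 2 to compound 4 (0.28 log units; within the scatter). Loss of two carbons here therefore does not move the number beyond the scatter, whereas loss of the chloro from compounds 1 and 2 did. Nothing given here bears on why this group behaves so.

As far as these compounds go, it remains open whether an amine, a methoxy or a carboxylic acid at this place would also stay within the scatter. From the compounds shown here alone, whether the same change holds alongside the 4-chlorophenyl of compound 1 also stays open.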